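A few compounds are considered here, and "the series" means these few. Any claim that something is new, unique, unknown or untested is made for them only; others in the source may bear on it.

Measured compounds:
Compound 1, `Cc1cc(=O)c2c(O)c(CN3CCN(C(=O)OC(C)(C)C)CC3)c(O)c([C@H]3CCN(C)C[C@H]3O)c2o1`, 1%
Compound 2, `Cc1oc2c([C@H]3CCN(C)C[C@H]3O)c(O)cc(O)c2c(=O)c1C(O)c1cccc(Cl)c1`, 31%

For the measured compounds named here, in a functional assay on PC-3 cells (Homo sapiens) for inhibition, read by MTT assay, with a stated time of 48 h, tested at 10 uM (a lower number here means less inhibition of growth, a higher number more inhibition of growth at the concentration tested), compound 2 stands highest of the two numbers known so far: compound 2 gives 31%, while compound 1 gives 1%, a gap beyond the usual scatter. Compound 3, `Cc1oc2c([C@H]3CCN(C)C[C@H]3O)c(O)cc(O)c2c(=O)c1C(O)c1c(Cl)cccc1Cl`, differs from compound 2 in one place: 2,6-dichlorophenyl in place of 3-chlorophenyl on a saturated chain carbon bound to an aromatic carbon and an oxygen on a saturated carbon. Going by the values given here, no measured pair shows this change, so the size of its effect is not known from the data. The step from compound 2 to compound 3 is expected to be small, within the scatter, estimated as a number 1 percentage points lower from compound 2 to compound 3 (within the scatter). Compound 3 is therefore expected to give about 30%, with an estimated range from 10% to 55%.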

Compound 3, percent growth inhibition at one concentration: 0%
Beside the measured number, compound 3's estimate is 30 percentage points above it, outside the stated range (below it).
By their numbers in this assay, from the lowest: compounds 3 and 1 (each within the scatter of the next); then compound 2.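

In this assay, for the compounds shown here, this position proves sensitive to the aryl group: 2,6-dichlorophenyl in place of 3-chlorophenyl on the saturated chain carbon gives a number 31 percentage points lower from compound 2 to compound 3 (beyond the scatter), the first single-place change that can be read. The growth inhibition of compound 2 therefore does not carry over to this close analogue. No available evidence bears on this loss.

As far as these compounds go, whether a plain phenyl or a 2-chlorophenyl on this carbon would retain the inhibition of compound 2 remains open. So does the effect of a pyridyl ring there.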